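Benzyl for thiophen-2-yl on the sulfonyl sulfur

The source may hold more compounds than are shown below. What is called first, only, known or untested is meant among the compounds shown, and "the series" means these compounds.

Measured so far:
compound 1 `COc1ccc(-c2ccc(OCc3cc(C(=O)O)oc3C)cc2)cc1OC`: 2800 nM
compound 2 `COc1ccc(-c2ccc(OCc3cc(C(=O)NS(=O)(=O)c4cccs4)oc3C)cc2)cc1`: 3.6 nM
compound 3 `COc1ccc(-c2ccc(OCc3cc(C(=O)NS(=O)(=O)c4c(C)noc4C)oc3C)cc2)c(C)c1`: 24 nM

In an assay on cells for displacement of a labelled ligand from prostaglandin E2 receptor EP4 subtype (Homo sapiens), read by scintillation counting (on this read-out higher numbers stand for weaker inhibition and lower numbers for stronger inhibition), compound 2 gives the lowest of the three numbers; compound 3 stands above it by a step beyond the scatter, and compound 1 stands far above both. Compound 4 `COc1ccc(-c2ccc(OCc3cc(C(=O)NS(=O)(=O)Cc4ccccc4)oc3C)cc2)cc1` has not yet been measured. It differs from compound 2 in one place: benzyl in place of thiophen-2-yl on a sulfonyl sulfur. Within the data shown here, no measured pair carries this change, so its size is not known from the series; compound 2 and compound 3 differ in more than one place and show only that their values differ. The expected step of a 2.2-fold higher number from compound 2 to compound 4 (0.35 log units; beyond the scatter) is a modest weakening, close to the edge of the scatter. For compound 4 the estimated value is 8 nM, with a range from 2.5 nM to 30 nM.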

Compound 4, inhibition constant: 3 nM
Beside the measured number, compound 4's estimate is 2.7-fold (0.43 log units) above it; measured number inside the range.
By their numbers in this assay, from the lowest: compounds 4 and 2 (each within the scatter of the next); then compound 3; then compound 1.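

In this assay, benzyl in place of thiophen-2-yl on the sulfonyl sulfur gives a 1.2-fold lower number from compound 2 to compound 4 (0.08 log units; within the scatter). This first one-place step in the series shows that the sulfonyl sulfur can carry either a six-membered aromatic ring of carbon only, held through benzyl, or a five-membered aromatic ring with a hetero atom, with values that cannot be told apart. No measurement shown bears on why the two groups read alike. Still open, going by these compounds, is how this assay responds to a cyclopropyl group on the sulfonyl sulfur, or to a benzyl carrying an amine.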